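Replacing a methylthiophene with a chlorophenyl in growth inhibition

This account rests on a few compounds, and the source may have more. Where it says the series, first, only, none or still open, it means among the compounds named here.

- Compound 1 `O=C(/C(=C\c1ccc(Cl)cc1)SCc1ccccc1Cl)c1ccc(Cl)cc1` gives 12000 nM as a number
- Compound 2 `Cc1ccc(/C=C(/SCc2ccc(F)cc2)C(=O)c2ccc(Cl)cc2)s1` gives > 100000 nM as a limit

Both values come from a functional assay on DU-145 cells (Homo sapiens) for inhibition, read by trypan blue exclusion, with a stated time of 96 h (a lower number here means a stronger inhibitor of growth, a higher number a weaker inhibitor of growth), and only compound 1 has a number there. Compound 2 reports > 100000 nM as a limit of the assay and has no number.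

Compound 3 `O=C(/C(=C\c1ccc(Cl)cc1)SCc1ccc(F)cc1)c1ccc(Cl)cc1` differs from compound 2 in one place (4-chlorophenyl in place of 5-methylthiophen-2-yl on a double-bonded chain carbon bound to a double-bonded chain carbon) with 4-chlorophenyl in place of 5-methylthiophen-2-yl on a double-bonded chain carbon bound to a double-bonded chain carbon. Within the data shown here, no measured step shows this change, but compound 1 also carries 4-chlorophenyl in that place and gives a number (12000 nM). A stronger inhibitor of growth is therefore expected, by more than the usual scatter, with the estimated step (an at least 10-fold lower number from compound 2 to compound 3 (1.00 log units; beyond the scatter)) resting on a limit. In this assay the estimate for compound 3 is 10000 nM within an expected range (2500 nM to 40000 nM).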

Compound 3, concentration for 50% growth inhibition: 10000 nM
Estimate against measurement, compound 3: no gap at the digits printed, and the stated range covers the measured number.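

In this assay, the direct step for 4-chlorophenyl in place of 5-methylthiophen-2-yl on a double-bonded chain carbon bound to a double-bonded chain carbon is an at least 10-fold lower number from compound 2 to compound 3 (1.00 log units; beyond the scatter), so this position responds to this change. The full size of that step cannot be read, because compound 2 stands at a limit of the assay and not at a number: the limit of > 100000 nM in this assay, at which 1 of the 3 values shown sits. The other new step, for 4-fluorophenyl in place of 2-chlorophenyl on a saturated chain carbon bound to a sulfur, is a 1.2-fold lower number from compound 1 to compound 3 (0.08 log units; within the scatter), which stays within the scatter.

The step swaps the ring and adds the chlorine at once, so the compounds shown do not separate the two. Going by these compounds, whether a plain phenyl or a pyridine ring at this position would match the 4-chlorophenyl, or an amine would be accepted on the saturated chain carbon bound to a sulfur, remains open.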